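Oxetane with a hydroxyl in place of the oxolane ring

A few compounds are considered here, and "the series" means these few. Any claim that something is new, unique, unknown or untested is made for them only; others in the source may bear on it.

Measured in an assay on HEK293 cells for inhibition of Leucine-rich repeat serine/threonine-protein kinase 2 variant G2019S (Homo sapiens), with a stated time of 48 h; a higher number here means a weaker inhibitor, a lower number a stronger inhibitor:
Compound 1 `Cc1c(Nc2nc(N)c3c(C#N)c(N4CCC[C@H]4C)n(C)c3n2)cnn1C` gives 260 nM.
Compound 2 `Cc1nn(C2COC2)cc1Nc1nc(N)c2c(C#N)c(N3CCC[C@H]3C)n(C)c2n1` gives 140 nM.
Compound 3 `Cc1c(Nc2nc(N)c3c(C#N)c(N4CCC[C@H]4C)n(C)c3n2)cnn1[C@H]1CCOC1` gives 51 nM.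

Compound 3 holds the lowest number of the three; compound 2 stands nearest and compound 1 furthest, both beyond the scatter. Compound 4 `Cc1c(Nc2nc(N)c3c(C#N)c(N4CCC[C@H]4C)n(C)c3n2)cnn1CC1(O)COC1` differs from compound 3 in one place: (3-hydroxyoxetan-3-yl)methyl in place of oxolan-3-yl on an aromatic nitrogen. Going by the values given here, no measured step covers this exact exchange. Among the compounds with values here, the steps that bear on it both start from compound 1: a 1.9-fold lower number from compound 1 to compound 2 (0.27 log units; within the scatter) and a 5.1-fold lower number from compound 1 to compound 3 (0.71 log units; beyond the scatter). The step to compound 3 lowers the number beyond the scatter, while the step to compound 2 stays within it. Within the data shown here, compound 4 carries a four-membered ring, as compound 2 does, together with a hydroxyl that no measured compound shows. Compound 4 is therefore expected to show a 2.0-fold higher number from compound 3 to compound 4 (0.29 log units; within the scatter). Compound 4 is estimated at 100 nM, with a range from 40 nM to 250 nM.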

Compound 4, half-maximal inhibitory concentration: 120 nM
Compound 4: the middle estimate sits 1.2-fold (0.08 log units) below what was measured; measured number inside the range.
By their numbers in this assay, from the lowest: compound 3; then compounds 4, 2 and 1 (each within the scatter of the next, the first and the last beyond it).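

In this assay, (3-hydroxyoxetan-3-yl)methyl on this aromatic nitrogen does not match oxolan-3-yl, with a 2.4-fold higher number from compound 3 to compound 4 (0.37 log units; beyond the scatter). It still improves on the methyl group, with a 2.2-fold lower number from compound 1 to compound 4 (0.34 log units; beyond the scatter), so a substituent carrying a hydrogen-bond donor can lower the number at this position. Nothing measured here explains either step. The compounds shown leave open whether the hydroxyl contributes at all, which an oxetan-3-ylmethyl group would test, and how an amine or a carboxylic acid on the same chain would compare.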